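From Methyl to 3-Hydroxypyrrolidin-1-yl on the Sulfonyl Sulfur

This account rests on a few compounds, and the source may have more. Where it says the series, first, only, none or still open, it means among the compounds named here.

In an ADME assay on CHO cells (Cricetulus griseus) for cytotoxicity, read by MTT assay (a higher number here means a weaker inhibitor, a lower number a stronger inhibitor), compound 3 `CS(=O)(=O)c1cccc(-c2ccc3nccc(-c4ccncc4)c3n2)c1` gives 13000 nM and cannot be told apart from compound 1 `O=S(=O)(NCC1COC1)c1cccc(-c2ccc3nccc(-c4ccncc4)c3n2)c1` at 16000 nM on the size of the step between them (a 1.2-fold lower number from compound 1 to compound 3 (0.09 log units; within the scatter)). Compound 2 `NS(=O)(=O)c1cccc(-c2ccc3nccc(-c4ccncc4)c3n2)c1` has the lowest of the three numbers at 2000 nM and the step up from it is clear (a 6.5-fold higher number from compound 2 to compound 3 (0.81 log units; beyond the scatter)).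

Compound 4 `O=S(=O)(c1cccc(-c2ccc3nccc(-c4ccncc4)c3n2)c1)N1CC[C@H](O)C1` has not yet been measured. The change that leads to it is 3-hydroxypyrrolidin-1-yl in place of methyl on a sulfonyl sulfur in short, 3-hydroxypyrrolidin-1-yl in place of methyl on a sulfonyl sulfur.

Among the measured compounds shown here, two measured steps bear on this change. Compound 1, like compound 4, carries a substituent on the sulfonamide nitrogen, and its number stays within the scatter of the methyl compound. Only compound 2, with its unsubstituted sulfonamide, stands apart (an 8.0-fold lower number from compound 1 to compound 2 (0.90 log units; beyond the scatter)). Compound 4 has no such unsubstituted nitrogen, so it is expected to sit with compound 1 rather than with compound 2. For the measured compounds named here, no compound with a ring on that nitrogen has been measured, so the range stays wide. The estimated change is a 1.2-fold lower number from compound 3 to compound 4 (0.07 log units; within the scatter) and no step beyond the scatter is expected in this assay. Compound 4 is expected at 11000 nM with an estimated range from 4000 nM to 30000 nM in this read-out.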

Compound 4, half-maximal inhibitory concentration: 9000 nM
The estimate for compound 4 lay 1.2-fold (0.09 log units) above the measured number, within the range that was stated.
By their numbers in this assay, from the lowest: compound 2; then compounds 4, 3 and 1 (each within the scatter of the next).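

In this assay, the first ring on the sulfonyl sulfur, a 3-hydroxypyrrolidin-1-yl group, cannot be told apart from methyl at this position (a 1.4-fold lower number from compound 3 to compound 4 (0.16 log units; within the scatter)). Nor can it be told apart from the open-chain ((oxetan-3-yl)methyl)amino group (a 1.8-fold lower number from compound 1 to compound 4 (0.25 log units; within the scatter)), so a ring, a chain and a plain methyl on the same sulfur all give numbers within the scatter of one another. The amino group of compound 2 now stands apart from a third neighbour (a 4.5-fold higher number from compound 2 to compound 4 (0.65 log units; beyond the scatter)), and among these four compounds it is the only group on the sulfonyl sulfur that does so.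

What sets the amino group apart from the other three remains unexplained, as nothing measured here speaks to it. Going by these compounds, it also remains open whether a single methyl on the sulfonamide nitrogen, or a plain pyrrolidin-1-yl group without the hydroxy, would read with compound 2 or with the cluster of compounds 1, 3 and 4.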